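This account rests on a few compounds, and the source may have more. Where it says the series, first, only, none or still open, it means among the compounds named here.

Measured in an ADME assay on PC-3 cells (Homo sapiens) for cytotoxicity, read by sulforhodamine B assay, with a stated time of 48 h, tested at 10 uM; on this read-out higher numbers stand for more inhibition at the one concentration tested (going by the name of the read-out) and lower numbers for less inhibition:
compound 1 `CCCCCCc1cn(C(c2ccccc2)c2cc3cc(Br)ccc3nc2OC)nn1` gives 2.32%
compound 2 `CCOC(=O)c1cn(C(c2ccccc2)c2cc3cc(Br)ccc3nc2OC)nn1` gives 16.1%
compound 3 `CCCCCc1cn(C(c2ccccc2)c2cc3cc(Br)ccc3nc2OC)nn1` gives 11.4%

On the numbers shown, compound 3 sits in the middle of the three, yet neither gap is beyond the scatter: the step of a number 4.7 percentage points lower from compound 2 to compound 3 (within the scatter) is within it, and so is the step of a number 9.1 percentage points higher from compound 1 to compound 3 (within the scatter). Going by the values given here, the only step beyond the scatter is a number 13.8 percentage points higher from compound 1 to compound 2 (beyond the scatter), a modest rise when an alkyl chain is swapped for ethoxycarbonyl on the five-membered ring.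

Compound 4 `COc1nc2ccc(Br)cc2cc1C(c1ccccc1)n1cc(-c2ccccc2C(F)(F)F)nn1` is the next member, not yet measured. It differs from compound 3 by 2-(trifluoromethyl)phenyl in place of pentyl on an aromatic carbon. Among the compounds with values here, the steps that bear on it are the two swaps at that same aromatic carbon, a number 13.8 percentage points higher from compound 1 to compound 2 (beyond the scatter) and a number 4.7 percentage points lower from compound 2 to compound 3 (within the scatter); the first is modest, the second within the scatter. No aryl group at this carbon has been measured, so the direction rests on those two alkyl-to-ester swaps alone. A small upward step is therefore expected, estimated as a number 4.6 percentage points higher from compound 3 to compound 4 (within the scatter), which may well fall within the scatter.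

For compound 4 the expected value in this assay is 16%, with a range from 2% to 34%.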

Compound 4, a percentage reported as inhibition, at one concentration (the size of the read-out at that concentration, not a potency): 17.4%
Compound 4: middle estimate off by 1.4 percentage points, on the low side; measured number inside the range.
By their numbers in this assay, from the lowest: compounds 1, 3, 2 and 4 (each within the scatter of the next, the first and the last beyond it).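

Working from this assay, the position on the aromatic carbon of the five-membered aromatic ring with 3 nitrogen now accepts a ring as well as a chain or an ester: 2-(trifluoromethyl)phenyl cannot be told apart from pentyl (a number 6 percentage points higher from compound 3 to compound 4 (within the scatter)) or from ethoxycarbonyl (a number 1.3 percentage points higher from compound 2 to compound 4 (within the scatter)). Hexyl is the only group here that separates from other groups at this carbon, and compound 4 now joins compound 2 in standing apart from it (a number 15.1 percentage points higher from compound 1 to compound 4 (beyond the scatter)), although compound 3, with pentyl, goes against any simple split of chains from non-chains by staying within the scatter of all three other compounds. No measurement shown gives a reason for these numbers.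

Open, going by these compounds, is whether plain phenyl at this carbon would read the same as 2-(trifluoromethyl)phenyl, which would show whether the trifluoromethyl group contributes anything to the read-out of compound 4. Also open, on these data alone, is whether a carboxylic acid, a primary amine or a chain longer than hexyl at this carbon would move the number clearly away from those of compound 2 and compound 4.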